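The source may report more compounds than this note shows. Statements on the series, on what has been measured and on what is new or still open speak of the compounds shown alone.

Measured in a functional assay on KB cells (Homo sapiens) for inhibition, read by sulforhodamine B assay, with a stated time of 72 h; a lower number here means a stronger inhibitor of growth, a higher number a weaker inhibitor of growth:
Compound 1 `CNC(=O)/C=C/c1ccncc1-c1ccc2ccccc2c1`: > 10000 nM (a limit)
Compound 2 `CCOC(=O)/C=C/c1ccncc1-c1ccc2ccccc2c1`: > 10000 nM (a limit)

Compound 2 stands at > 10000 nM, which is a limit of the assay and not a number. Among the compounds with values here, the series so far reads: the limit of > 10000 nM in this assay, at which 2 of the 2 values shown sit. Compound 3 `COC1CN(C(=O)/C=C/c2ccncc2-c2ccc3ccccc3c2)C1` differs from compound 2 in one place: 3-methoxyazetidin-1-yl in place of ethoxy on a carbonyl carbon. Within the data shown here, the one measured step that bears on this, a step that the two limits leave unreadable from compound 1 to compound 2, is also a change on a carbonyl carbon, but it offers no size to carry over. On that step, no shift beyond the scatter is expected in this assay, in either direction, and the assay will most likely report only a limit again. The expected step is a number no higher from compound 2 to compound 3 (the limit leaves the size open). The estimate for compound 3 is 10000 nM, with an expected range of 3000 nM to 30000 nM.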

Compound 3, concentration for 50% growth inhibition: > 10000 nM
Compound 3 gave a limit, no number (the forecaster's own chance of this, stated with the estimate: 85%); the middle value sits exactly at the limit.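

In this assay no step among compound 1, compound 2 and compound 3 can be read, and the series now reads: the limit of > 10000 nM in this assay, at which 3 of the 3 values shown sit.

The compounds shown leave open how far apart these three lie, and whether any group on the carbonyl carbon gives a readable number.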